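The compounds below may be only part of what the source reports. "The series", "measured", "known", "first", "only" and "open" are said of these compounds alone.

Among the compounds with values here, compound 1 `Cc1cn([C@@H]2O[C@H](CO)[C@@]3(OS(=O)(=O)C=C3NC(=O)NC(=O)c3ccccc3)[C@H]2O[Si](C)(C)C(C)(C)C)c(=O)n(C)c1=O` is the one member of this set with a numeric result: in an ADME assay on HEL cells (Homo sapiens) for cytotoxicity, with a stated time of 3 days (on this read-out higher numbers stand for lower toxicity in this test and lower numbers for higher toxicity in this test), compound 1 gives 16000 nM. For compound 2 `Cc1cn([C@@H]2O[C@H](CO[Si](C)(C)C(C)(C)C)[C@@]3(OS(=O)(=O)C=C3NC(=O)NC(=O)c3ccccc3)[C@H]2O[Si](C)(C)C(C)(C)C(C)C)c(=O)n(C)c1=O` this assay reports only a limit, >= 100000 nM. For compound 3 `Cc1cn([C@@H]2O[C@H](COC(=O)c3ccccc3)[C@@]3(OS(=O)(=O)C=C3NC(=O)NC(=O)c3ccccc3)[C@H]2O)c(=O)n(C)c1=O` this assay likewise reports only a limit, > 100000 nM. Compound 4 `Cc1cn([C@@H]2O[C@H](COCc3ccccc3)[C@@]3(OS(=O)(=O)C=C3NC(=O)NC(=O)c3ccccc3)[C@H]2O[Si](C)(C)C(C)(C)C)c(=O)n(C)c1=O` differs from compound 1 by benzyl in place of hydrogen on an oxygen on a saturated carbon. Within the data shown here, no step between measured compounds is available, so the expectation rests on compound 1 alone together with the limits of compound 2 and compound 3. The step from compound 1 to compound 4 is expected to raise the number beyond the scatter, a 3.1-fold higher number from compound 1 to compound 4 (0.49 log units; beyond the scatter). Compound 4 is therefore estimated at 50000 nM, within a range of 15000 nM to 150000 nM.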

Compound 4, half-maximal cytotoxic concentration: > 50000 nM
Compound 4 gave a limit, no number (the forecaster's own chance of this, stated with the estimate: 45%); the middle value sits exactly at the limit.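

Within the data shown here, compound 4 gives the first single-place comparison at this position: in this assay, hydroxymethyl to (benzyloxy)methyl gives an at least 3.1-fold higher number from compound 1 to compound 4 (0.49 log units; beyond the scatter). Capping this oxygen with benzyl therefore moves the result towards lower toxicity in this test, which compound 2 and compound 3 could not show, as each differs from compound 1 in more than one place. For compound 4, > 50000 nM is a limit, not a number.

On these data alone, how far the step truly reaches stays unknown because the result ends at a limit: the limit of > 50000 nM in this assay, at which 1 of the 4 values shown sits. Whether a smaller group such as methyl, or a chain carrying an amine or a carboxylic acid, would act like benzyl on this oxygen remains open.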